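Amide aryl variation and an expected antiproliferative value

The source may report more compounds than this note shows. Statements on the series, on what has been measured and on what is new or still open speak of the compounds shown alone.

Compound 1 `Cc1cccc(C(=O)Nc2cccc(-c3oc4cc(-c5ccc(F)cc5)ccc4c(=O)c3O)c2)c1` in a functional assay on HepG2 cells (Homo sapiens) for antiproliferative activity, read by CCK-8 assay, with a stated time of 72 h; on this read-out lower numbers stand for stronger inhibition and higher numbers for weaker inhibition: 13500 nM
Compound 2 `CCc1ccc(C(=O)Nc2cccc(-c3oc4cc(-c5ccc(F)cc5)ccc4c(=O)c3O)c2)cc1`: 20600 nM
Compound 3 `O=C(Nc1cccc(-c2oc3cc(-c4ccc(F)cc4)ccc3c(=O)c2O)c1)c1ccc(Cl)nc1`: 4610 nM

Compound 3 gives the lowest number of the three: a 2.9-fold lower number from compound 1 to compound 3 (0.47 log units; beyond the scatter) and a 4.5-fold lower number from compound 2 to compound 3 (0.65 log units; beyond the scatter), both beyond the scatter, while a 1.5-fold higher number from compound 1 to compound 2 (0.18 log units; within the scatter) stays within it. Compound 4 `O=C(Nc1cccc(-c2oc3cc(-c4ccc(F)cc4)ccc3c(=O)c2O)c1)c1ccc([N+](=O)[O-])cc1` differs from compound 3 by 4-nitrophenyl in place of 6-chloropyridin-3-yl on a carbonyl carbon. Among the measured compounds shown here, no measured step exchanges an aryl group for a 4-nitrophenyl, so the three steps bear on this change only in showing that swapping the aryl group on the carbonyl carbon moves this assay by modest amounts in either direction. Compound 4 is therefore expected to sit between compound 3 and compound 1, a step of a 1.7-fold higher number from compound 3 to compound 4 (0.24 log units; within the scatter). The estimate for compound 4 is 8000 nM, with a range from 2500 nM to 25000 nM.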

Compound 4, half-maximal inhibitory concentration: 1860 nM
Compound 4: the middle estimate sits 4.3-fold (0.63 log units) above what was measured; the whole stated range lies above it.
By their numbers in this assay, from the lowest: compound 4; then compound 3; then compounds 1 and 2 (each within the scatter of the next).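

In this assay, among the compounds shown here, the 4-nitrophenyl group on the carbonyl carbon reaches lower than any earlier aryl group, with a 2.5-fold lower number from compound 3 to compound 4 (0.39 log units; beyond the scatter) and a 7.3-fold lower number from compound 1 to compound 4 (0.86 log units; beyond the scatter) and then an 11-fold lower number from compound 2 to compound 4 (1.04 log units; beyond the scatter) as the one large step. For the compounds shown here, compound 4 is therefore the most potent of the four, and the spread at this position is wider than the earlier compounds showed. Nothing available explains this order.

Compound 3 and compound 4 differ in both the ring and its substituent, so the share of the nitro group remains unresolved. As far as these compounds go, whether a 4-aminophenyl or 4-cyanophenyl group here would match compound 4 also stays open.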